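Cyano to acetamido exchange on two pyridinyl cores

The source may hold more compounds than are shown below. What is called first, only, known or untested is meant among the compounds shown, and "the series" means these compounds.

Four compounds share one core and differ at two places. Compound 1 `N#Cc1ccc(S(=O)(=O)N2C/C(=C\c3cccnc3)C(=O)/C(=C/c3ccccc3F)C2)cc1` and compound 2 `CC(=O)Nc1ccc(S(=O)(=O)N2C/C(=C\c3cccnc3)C(=O)/C(=C/c3ccccc3F)C2)cc1` carry pyridin-3-yl on one arm; compound 3 `N#Cc1ccc(S(=O)(=O)N2C/C(=C\c3ccncc3)C(=O)/C(=C/c3ccccc3F)C2)cc1` and compound 4 `CC(=O)Nc1ccc(S(=O)(=O)N2C/C(=C\c3ccncc3)C(=O)/C(=C/c3ccccc3F)C2)cc1` carry pyridin-4-yl there. In a functional assay on SMMC-7721 cells (Homo sapiens) for cytotoxicity, read by MTT assay, with a stated time of 24 h (a higher number here means a weaker inhibitor, a lower number a stronger inhibitor), compound 1 gives 15400 nM, compound 2 gives 10900 nM and compound 3 gives 16200 nM. Compound 4 has not been measured in this assay.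

The two cores differ by pyridin-4-yl in place of pyridin-3-yl on a double-bonded chain carbon bound to a double-bonded ring carbon, and in this assay this made a 1.1-fold higher number from compound 1 to compound 3 (0.02 log units; within the scatter). Compound 3 has the highest of the three numbers, but all three lie within the scatter of one another, so no order among them is claimed.

The change under study is acetamido in place of cyano on an aromatic carbon, which in this assay made a 1.4-fold lower number from compound 1 to compound 2 (0.15 log units; within the scatter). The same change is made once more, from compound 3 to compound 4, as acetamido in place of cyano on an aromatic carbon. The place of the change reads the same word for word in both pairs, so the surroundings of the exchanged group do not differ between the measured pair and the unmeasured one; among these compounds the change occurs two times in all.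

The estimated step of a 1.4-fold lower number from compound 3 to compound 4 (0.15 log units; within the scatter) is expected to stay within the scatter because a 1.4-fold lower number from compound 1 to compound 2 (0.15 log units; within the scatter) did. On that basis compound 4 is expected to give 11500 nM in this assay, with a likely range from 6000 nM to 22000 nM.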

Compound 4, half-maximal inhibitory concentration: 13400 nM
Compound 4: the middle estimate sits 1.2-fold (0.07 log units) below what was measured, and the stated range covers the measured number.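

In this assay, acetamido in place of cyano gave a 1.2-fold lower number from compound 3 to compound 4 (0.08 log units; within the scatter), which agrees with the earlier step on the other core: the same change on two cores in this assay, a 1.4-fold lower number (0.15 log units; within the scatter) from compound 1 to compound 2 and a 1.2-fold lower number (0.08 log units; within the scatter) from compound 3 to compound 4, 1.2-fold (0.07 log units) apart, within the scatter of two such steps. Pyridin-4-yl in place of pyridin-3-yl gave a 1.2-fold higher number from compound 2 to compound 4 (0.09 log units; within the scatter), and this exchange also reads alike with either group on the aromatic ring: the same change on two cores in this assay, a 1.1-fold higher number (0.02 log units; within the scatter) from compound 1 to compound 3 and a 1.2-fold higher number (0.09 log units; within the scatter) from compound 2 to compound 4, 1.2-fold (0.07 log units) apart, within the scatter of two such steps. Within these four compounds, neither exchange gives a step beyond the scatter on either core, which supports carrying that null reading between the two cores but does not show that either exchange has a real effect of a fixed size or that the reading would hold on a third core.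

Still open, on these data alone, is whether an amine or a carboxylic acid in place of cyano, a longer chain in place of the acetyl part of acetamido, or pyridin-2-yl on the pyridinyl arm would give a step beyond the scatter. Also open, as far as these compounds go, is whether the two exchanges would read the same way with a group other than the fluorophenyl on the remaining arm, or in any read-out other than this assay.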